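A few compounds are considered here, and "the series" means these few. Any claim that something is new, unique, unknown or untested is made for them only; others in the source may bear on it.

In a functional assay on A549 cells (Homo sapiens) for inhibition, read by sulforhodamine B assay, with a stated time of 48 h (on this read-out higher numbers stand for weaker inhibition of growth and lower numbers for stronger inhibition of growth), compound 1 `CCCCCCCCCCCC[C@@H](O)[C@H]1CC[C@H]([C@H](O)CCCCCCCCCCN(C)C(=O)c2ccnn2C)O1` gives 8510 nM, and compound 2 `CCCCCCCCCCCC[C@@H](O)[C@H]1CC[C@H]([C@H](O)CCCCCCCCCCNCc2ccnn2C)O1` gives 8710 nM. On these two numbers compound 2 sits together with compound 1 inside the usual scatter, so the pair cannot be told apart. Among the measured compounds shown here, the only measured step, a 1.0-fold higher number from compound 1 to compound 2 (0.01 log units; within the scatter), exchanged the group at the far end of the long chain and moved nothing beyond the scatter. Compound 3 `CCCCCCCCCCCC[C@@H](O)[C@H]1CC[C@H]([C@H](O)CCCCCCCCCCOC(=O)c2ccnn2C)O1` has not been measured; it differs from compound 2 by ((1-methyl-1H-pyrazol-5-yl)carbonyl)oxy in place of ((1-methyl-1H-pyrazol-5-yl)methyl)amino on a saturated chain carbon, ten or more bonds along the chain from an oxygen on a saturated carbon and a saturated ring carbon. For the measured compounds named here, that single step is the only guide, and it was flat. Compound 1 also carries a carbonyl on the same pyrazole and gives 8510 nM, close to compound 2, which supports a flat outcome. For compound 3 a step of no size beyond the scatter is expected, a 1.0-fold lower number from compound 2 to compound 3 (0.01 log units; within the scatter). Compound 3 is estimated to give 8600 nM, within 4000 nM to 18000 nM.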

Compound 3, concentration for 50% growth inhibition: 56200 nM
Compound 3: middle estimate off by 6.5-fold (0.82 log units), on the low side; measured number above the stated range.
By their numbers in this assay, from the lowest: compounds 1 and 2 (each within the scatter of the next); then compound 3.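

In this assay, the atom joining the pyrazole group to the long chain turns out to matter, which the flat step between the two nitrogen-linked compounds could not reveal: ((1-methyl-1H-pyrazol-5-yl)carbonyl)oxy in place of ((1-methyl-1H-pyrazol-5-yl)methyl)amino gives a 6.5-fold higher number from compound 2 to compound 3 (0.81 log units; beyond the scatter). A carbonyl on the pyrazole is not enough to produce this weaker growth inhibition, since compound 1 also has one, and exchanging its methyl-bearing nitrogen for oxygen gives a 6.6-fold higher number from compound 1 to compound 3 (0.82 log units; beyond the scatter). Nothing available explains why this exchange weakens growth inhibition.

From the compounds shown here alone, with a single oxygen-linked compound, it remains open whether the nitrogen is what counts or whether this particular oxygen link is what differs. An ether link or an amide keeping its hydrogen on nitrogen, at the same place on the chain, would help separate these two readings.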